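Trifluoromethyl for Methyl on the Aryl Ring

This account rests on a few compounds, and the source may have more. Where it says the series, first, only, none or still open, it means among the compounds named here.

Measured so far:
- compound 1, `CCc1nc(-c2cnc(OC)nc2OC)c(CC)nc1NC(CC)CC`: 0.117 h
- compound 2, `CCc1nc(-c2ccc(C)cc2OC)c(CC)nc1NC(CC)CC`: 0.183 h
- compound 3, `CCc1nc(-c2ccc(OC)cc2O)c(CC)nc1NC(CC)CC`: 0.3 h

Three compounds share one core and differ only in the aromatic group attached to it. They were tested in an in vitro ADME assay on microsomes (Homo sapiens) for metabolic stability; on this read-out lower numbers stand for a shorter-lived compound and higher numbers for a longer-lived compound. In this assay compound 1 gives 0.117 h, compound 2 gives 0.183 h, and compound 3 gives 0.3 h. The number for compound 2 sits between the other two, and its gaps to compound 1 and to compound 3 both fall within the usual scatter of this assay, so none of the three can be set apart from the others on these data.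

Compound 4, `CCc1nc(-c2ccc(C(F)(F)F)cc2OC)c(CC)nc1NC(CC)CC`, has not yet been measured. Compared with compound 2 the change is trifluoromethyl in place of methyl on an aromatic carbon. No pair of measured compounds differs in just this way, so there is no measured step to lean on; the three measured numbers lie close together and give no strong reason to expect a large move in either direction.

For compound 4 in this assay the expectation is a small shift upward, a 1.6-fold higher number from compound 2 to compound 4 (0.21 log units; within the scatter), that may not exceed the scatter. The estimate for compound 4 is 0.3 h, with a range from 0.12 h to 0.7 h.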

Compound 4, half-life: 0.183 h
Beside the measured number, compound 4's estimate is 1.6-fold (0.21 log units) above it; measured number inside the range.
By their numbers in this assay, from the lowest: compounds 1, 2, 4 and 3 (each within the scatter of the next, the first and the last beyond it).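

Going by these compounds alone, compound 2 and compound 4 form the first pair here that differs in only one place, so this change can finally be read on its own rather than inferred from compounds that differ in several ways. In this assay, replacing methyl with trifluoromethyl on this aromatic carbon, para to a large group and meta to a methoxy group, gives no change at the digits printed from compound 2 to compound 4 (within the scatter), so at this position and on this read-out the two groups cannot be told apart. No supporting measurement is available to explain this outcome.

On these data alone, what remains open is whether the position would respond in the same way to a different group, such as a chlorine atom, a nitrile, an amine or a longer chain. It is also unclear whether the same exchange of methyl for trifluoromethyl would give a similar result elsewhere on the ring or on the aromatic groups of compound 1 and compound 3, since this single pair speaks only for its own position.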